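Cytotoxicity in the boronic-ester aryl ketone series

The source may report more compounds than this note shows. Statements on the series, on what has been measured and on what is new or still open speak of the compounds shown alone.

Compound 1 `O=C(c1ccn(-c2ccc3c(c2)B(O)OC3)c1)c1ccc(Cl)cc1Cl` is measured in an ADME assay on L929 cells (Mus musculus) for cytotoxicity, read by resazurin assay, with a stated time of 72 h (a higher number here means a weaker inhibitor, a lower number a stronger inhibitor), where it reaches only a limit of the assay: compound 1 gives > 10 ug/mL. Compound 1 stands at the weak end of what is shown, at the limit of > 10 ug/mL in this assay, at which 1 of the 2 values shown sits. Compound 2 `COc1cc(C(=O)c2ccn(-c3ccc4c(c3)B(O)OC4)c2)cc(OC)c1OC` in this assay gives 1.15 ug/mL. Compound 3 `O=C(c1ccn(-c2ccc3c(c2)B(O)OC3)c1)c1cccs1` is not yet measured; it differs from compound 1 by thiophen-2-yl in place of 2,4-dichlorophenyl on a carbonyl carbon. Within the data shown here, no measured step covers such a change, and from compound 1 to compound 3 the step in this assay is expected to be small, a number no higher from compound 1 to compound 3 (the limit leaves the size open), not beyond the scatter. Compound 3 is therefore estimated at 10 ug/mL, ranging from 3 ug/mL to 30 ug/mL.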

Compound 3, half-maximal inhibitory concentration: > 10 ug/mL
Compound 3 ended at the assay's limit; the forecaster's own chance of this, stated with the estimate: 60%; the middle value sits exactly at the limit.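

Among these compounds, compound 1 and compound 3 both stand at a limit of this assay, so no step between them can be read: the limit of > 10 ug/mL in this assay, at which 2 of the 3 values shown sit.

Still open, as far as these compounds go, is what thiophen-2-yl in place of 2,4-dichlorophenyl on a carbonyl carbon does in this assay.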